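The source may report more compounds than this note shows. Statements on the series, on what has been measured and on what is new or still open speak of the compounds shown alone.

Measured in a functional assay on the whole organism with Rattus norvegicus as the target; a lower number here means that less compound is needed, a higher number that more compound is needed for the effect:
- compound 1 `O=C(O)C(=O)Nc1nc(-c2ccccc2)cs1`: > 3 mg/kg, a limit and not a number
- compound 2 `O=C(O)C(=O)Nc1nc(-c2ccc(O)cc2)cs1`: about 0.1 mg/kg
- compound 3 `CCOC(=O)C(=O)Nc1nc(-c2ccc(N(C)C)cc2)cs1`: about 0.3 mg/kg

Compound 3 at about 0.3 mg/kg has a higher number than compound 2 at about 0.1 mg/kg, a gap beyond the scatter. Compound 1 stands at the limit of > 3 mg/kg in this assay, at which 1 of the 3 values shown sits.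

Compound 4 `CCCC(=O)Nc1ccc(-c2csc(NC(=O)C(=O)OCC)n2)cc1` follows from compound 3 with (propylcarbonyl)amino in place of dimethylamino on an aromatic carbon. Among the compounds with values here, the one measured step that bears on this is a change on an aromatic carbon, hydroxy in place of hydrogen, an at least 30-fold lower number from compound 1 to compound 2 (1.47 log units; beyond the scatter). It is large and rests on a limit, so it shows that such a change can matter but gives no direction here. In this assay the expected result is a 1.3-fold higher number from compound 3 to compound 4 (0.12 log units; within the scatter), with no shift beyond the scatter as the likeliest outcome, though the uncertainty is wide. For compound 4 the estimated value is 0.4 mg/kg, expected between 0.1 mg/kg and 1.5 mg/kg.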

Compound 4, dose for half-maximal effect: < 0.3 mg/kg
Compound 4: only a limit was reported; the forecaster's own chance of this, stated with the estimate: 15%; middle value at least 1.3-fold (0.12 log units) from the limit.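

In this assay compound 4 gives < 0.3 mg/kg, a limit and not a number. The step reads a number no higher from compound 3 to compound 4 (the limit leaves the size open), so on this aromatic carbon, para to a large group, dimethylamino can give way to the larger (propylcarbonyl)amino, which brings a hydrogen-bond donor, without a rise in the number. The earlier compounds shown here showed only hydroxy in place of hydrogen at this place. As far as these compounds go, the size of the step stays open, as does the effect of a free amine or a longer acyl chain here, or of a carboxylic acid in place of the ethyl ester of compound 4.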